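Swapping chloro for methyl on the thiazole of compound 2

The source may report more compounds than this note shows. Statements on the series, on what has been measured and on what is new or still open speak of the compounds shown alone.

Measured so far:
- compound 1, `Cc1cnc(NC(=O)CCCOc2cccc(C#N)c2)s1`: 460 mL.min-1.g-1
- compound 2, `O=C(CCCOc1ccccc1)Nc1ncc(Cl)s1`: 814 mL.min-1.g-1

In an ADME assay on microsomes from liver (Mus musculus) for metabolic stability, read by LC-MS, using NADPH, tested at 1 uM (on this read-out higher numbers stand for fast clearance and lower numbers for slow clearance), compound 2 gives 814 mL.min-1.g-1. That is the higher of the two numbers recorded, yet compound 1, with 460 mL.min-1.g-1 in this assay, sits close enough that the two values fall within the usual scatter of this kind of measurement, so no order between them can be claimed.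

Compound 3, `Cc1cnc(NC(=O)CCCOc2ccccc2)s1`, has not yet been measured. It differs from compound 2 in one place: methyl in place of chloro on an aromatic carbon

Within the data shown here, no pair of measured compounds differs in exactly one place, so there is no measured step to lean on. Compound 3 carries the same 5-methyl-1,3-thiazol-2-yl group as compound 1, and in this assay compound 1 gives 460 mL.min-1.g-1, which is a point in favour of a number in the same broad region as the two already seen.

For compound 3 the expectation is therefore a step of a 1.3-fold lower number from compound 2 to compound 3 (0.12 log units; within the scatter) that stays within the scatter. The estimated value for compound 3 in this assay is 620 mL.min-1.g-1, in a range from 330 mL.min-1.g-1 to 1200 mL.min-1.g-1.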

Compound 3, intrinsic clearance in microsomes: 815 mL.min-1.g-1
Compound 3: middle estimate off by 1.3-fold (0.12 log units), on the low side; measured number inside the range.
By their numbers in this assay, from the lowest: compounds 1, 2 and 3 (each within the scatter of the next).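

Putting the 5-methyl-1,3-thiazol-2-yl group where the 5-chloro-1,3-thiazol-2-yl group stood gives a 1.0-fold higher number from compound 2 to compound 3 (0.00 log units; within the scatter) in this assay and so, on this read-out, chloro and methyl cannot be told apart at this aromatic carbon next to the ring sulfur. Compound 3 also links compound 1 to the others through a single difference elsewhere: with the 5-methyl-1,3-thiazol-2-yl group kept, hydrogen in place of cyano on an aromatic carbon gives a 1.8-fold higher number from compound 1 to compound 3 (0.25 log units; within the scatter) and this difference likewise cannot be separated from the scatter. Nothing measured here offers an explanation for either result.

From the compounds shown here alone, it remains open whether a different kind of group on this same carbon, such as an amine, a methoxy group or a carboxylic acid, would move the clearance number clearly beyond the scatter. The compounds also leave open what a shorter or longer chain between the amide and the ether oxygen would do, since that part stays the same in all of them.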